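The source may hold more compounds than are shown below. What is called first, only, known or untested is meant among the compounds shown, and "the series" means these compounds.

In an assay for inhibition of alpha-N-acetylgalactosaminidase (Gallus gallus), tested at 1000 uM (on this read-out lower numbers stand for less inhibition and higher numbers for more inhibition at the one concentration tested (going by the name of the read-out)), compound 1 `O=C(O)[C@@H]1NCC=C[C@@H]1O` gives 1.3%, compound 2 `O=C(O)[C@@H]1NCC=C[C@H]1O` gives 3.2% and compound 3 `O=C(O)[C@@H]1NC[C@@H](O)[C@@H](O)[C@@H]1O` gives 7.2%. Compound 2 stands second highest of the three numbers, its nearest neighbour being compound 1 and its furthest compound 3, both of them within the scatter of it. Compound 4 `O=C(O)[C@H]1NCC=C[C@@H]1O` has not yet been measured in this assay. Compared with compound 2, (the two compounds have the same atoms and bonds and differ only in configuration as drawn: 2 of 2 stereo elements differ (all stereocentres are inverted: mirror images); a stereocentre at a saturated ring carbon is drawn R in compound 2 and S in compound 4; a stereocentre at a saturated ring carbon is drawn R in compound 2 and S in compound 4); the two are mirror images. Within the data shown here, the only measured step between compounds that differ in one place bears directly on this: because a number 1.9 percentage points higher from compound 1 to compound 2 (within the scatter) stayed within the scatter, and that step rests on (the fact that compounds 1 and 2 differ only in the configuration as drawn), a further change of configuration alone in compound 4 gives no ground to expect a step beyond the scatter in either direction, all three measured numbers sitting low. Compound 4 is therefore expected to give about 3.5% in this assay, with a range from 0% to 12%. The step of a number 0.3 percentage points higher from compound 2 to compound 4 (within the scatter) is thus estimated to remain within the scatter.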

Compound 4, a percentage reported as inhibition, at one concentration (the size of the read-out at that concentration, not a potency): 25%
For compound 4 the middle estimate is 21.5 percentage points below the measured one, and the stated range ends below it.
By their numbers in this assay, from the lowest: compounds 1, 2 and 3 (each within the scatter of the next); then compound 4.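

In this assay, configuration alone now proves to matter on the shared core: inverting one stereocentre at a saturated ring carbon gives a number 23.7 percentage points higher from compound 1 to compound 4 (beyond the scatter), whereas inverting the other had given only a number 1.9 percentage points higher from compound 1 to compound 2 (within the scatter). The mirror-image pair likewise separates, with a number 21.8 percentage points higher from compound 2 to compound 4 (beyond the scatter), so this read-out tells the two apart, though the step remains modest. No atom enters or leaves, so the gain can be tied only to the arrangement as drawn: the fact that compounds 1 and 4 differ only in the configuration as drawn.

On these data alone, it remains open whether this configuration would keep its advantage with a methyl ester or an amide in place of the carboxylic acid. A percentage at one concentration also leaves the potency of compound 4 undefined.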